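The source may report more compounds than this note shows. Statements on the series, on what has been measured and on what is new or still open speak of the compounds shown alone.

Measured compounds:
- Compound 1 `CCOc1cc(C(=O)OCc2ccc(-c3ccc(C)cc3)o2)cc(OCC)c1OCC`: in an assay on isolated protein for inhibition of high affinity 3',5'-cyclic-AMP phosphodiesterase 7A (Homo sapiens), read by scintillation proximity assay and cAMP accumulation, with a stated time of 20 min, tested at 10 uM (on this read-out higher numbers stand for more inhibition at the one concentration tested (going by the name of the read-out) and lower numbers for less inhibition), compound 1 gives 16.4%.
- Compound 2 `COc1cc(COC(=O)c2ccco2)cc(OC)c1OC`: in this assay compound 2 gives 10%.

Compound 2 holds the lowest of the two numbers recorded so far, but its nearest neighbour, compound 1, sits only slightly higher and within the scatter, so no order between the two can be claimed. Compound 3 `COc1cc(COC(=O)c2ccc(-c3ccccc3C(F)(F)F)o2)cc(OC)c1OC` is the next compound to be measured. It differs from compound 2 in one place: 2-(trifluoromethyl)phenyl in place of hydrogen on an aromatic carbon. Among the compounds with values here, no step between measured compounds is available, so the size of this change can only be gauged from what the two values show. Compound 1 also carries an aromatic ring at the corresponding place of its core, with other groups elsewhere, and its value lies within the scatter of compound 2. In this assay a small step is expected, upward if anything, and possibly none beyond the scatter. Compound 3 is estimated at 18%, between 4% and 36%. The expected step is a number 8 percentage points higher from compound 2 to compound 3 (within the scatter).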

Compound 3, a percentage reported as inhibition, at one concentration (the size of the read-out at that concentration, not a potency): 54.9%
Estimate against measurement, compound 3: 36.9 percentage points below, outside the stated range (above it).
By their numbers in this assay, from the lowest: compounds 2 and 1 (each within the scatter of the next); then compound 3.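

In this assay, the aromatic carbon next to the ring oxygen of the five-membered aromatic ring is a place where a single change moves the read-out clearly: 2-(trifluoromethyl)phenyl in place of hydrogen gives a number 44.9 percentage points higher from compound 2 to compound 3 (beyond the scatter). Within the data shown here, the two earlier compounds allowed no order, so this is the first sign that substitution at this carbon matters for inhibition at the one concentration tested. Nothing measured on these compounds accounts for the size of this step.

On these data alone, it remains open how much of the step belongs to the phenyl ring itself and how much to the trifluoromethyl group, which a plain phenyl, or a methyl or chlorine in place of the trifluoromethyl, would separate. Also open, as far as these compounds go, is whether the gain survives replacing the ester with an amide, and a single-concentration percentage gives no potency.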